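A few compounds are considered here, and "the series" means these few. Any claim that something is new, unique, unknown or untested is made for them only; others in the source may bear on it.

Measured so far in a functional assay, read by spectrophotometry, with a stated time of 6 min; a lower number here means a stronger inhibitor, a higher number a weaker inhibitor:
- compound 1 `CCCCCCOc1cc(OC)c(Br)cc1C(C)=O`: 35700000 nM
- compound 2 `CCCCCCCCOc1cc(OC)c(Br)cc1C(C)=O`: 32000000 nM
- compound 3 `CCCCCCCCCCOc1cc(OC)ccc1C(C)=O`: 41700000 nM

Compound 4 `CCCCCCCCCCCCOc1cc(OC)ccc1C(C)=O` is not yet measured.

From compound 1 to compound 2 the change is ethyl in place of hydrogen on a saturated chain carbon, six bonds along the chain from an oxygen on an aromatic ring; in this assay it gave a 1.1-fold lower number from compound 1 to compound 2 (0.05 log units; within the scatter). The change from compound 3 to compound 4 is ethyl in place of hydrogen on a saturated chain carbon, ten or more bonds along the chain from an oxygen on an aromatic ring, the same kind of change, though at a different place along the chain. How the core of compound 3 differs from the core of compound 1 is not broken down here. The three values of compound 1, compound 2 and compound 3 lie within the scatter of one another, so no order among them is claimed.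

For compound 4 the expected step in this assay is a 1.1-fold lower number from compound 3 to compound 4 (0.04 log units; within the scatter), resting on the step of a 1.1-fold lower number from compound 1 to compound 2 (0.05 log units; within the scatter) and on compound 3 at 41700000 nM. Compound 4 is thus estimated at 38000000 nM, between 20000000 nM and 75000000 nM.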

Compound 4, half-maximal inhibitory concentration: 40700000 nM
Beside the measured number, compound 4's estimate is 1.1-fold (0.03 log units) below it; the range from low to high includes it.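

In this assay ethyl in place of hydrogen gives a 1.0-fold lower number from compound 3 to compound 4 (0.01 log units; within the scatter) and stays within the scatter on the core of compound 3, as it does on the core of compound 1. The two steps set side by side read: the same change on two cores in this assay, a 1.1-fold lower number (0.05 log units; within the scatter) from compound 1 to compound 2 and a 1.0-fold lower number (0.01 log units; within the scatter) from compound 3 to compound 4, 1.1-fold (0.04 log units) apart, within the scatter of two such steps. This shows that the change leaves the number unresolved from scatter on both cores, at two different places along the chain; it does not show that a step of readable size would carry from one core to the other.

Still open, going by these compounds, is whether a much shorter chain, or a chain ending in an amine or a carboxylic acid, would move the number beyond the scatter. No pair shown isolates the difference between the two cores.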